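The source may hold more compounds than are shown below. What is called first, only, known or untested is meant among the compounds shown, and "the series" means these compounds.

Of the compounds shown here, two of one shared core have been measured so far. Compound 1, `N[C@@H]1CCN(c2cc3c(cc2F)c(=O)c(C(=O)O)cn3Cc2ccc(-c3ccccc3)cc2)C1`, gives 63600 nM in an assay on isolated protein for inhibition of DNA topoisomerase 1 (Homo sapiens), with a stated time of 15 min; a higher number here means a weaker inhibitor, a lower number a stronger inhibitor. Compound 2, `O=C(O)c1cn(Cc2ccc(-c3ccccc3)cc2)c2cc(N3CC4CNCC4C3)c(F)cc2c1=O`, gives 33300 nM in this assay, the lowest of the two numbers, though the step of a 1.9-fold lower number from compound 1 to compound 2 (0.28 log units; within the scatter) lies within the scatter, so the two cannot be ranked against each other. Compound 3, `CNCCNc1cc2c(cc1F)c(=O)c(C(=O)O)cn2Cc1ccc(-c2ccccc2)cc1`, has not been measured yet. It differs from compound 2 in one place: a group of 5 heavy atoms (3 carbon, 2 nitrogen; no ring) in place of a group of 8 heavy atoms (6 carbon, 2 nitrogen; 2 five-membered non-aromatic rings with 1 hetero atom each), on an aromatic carbon. Within the data shown here, only the single step from compound 1 to compound 2 bears on this change, and it shows that swapping one amine-bearing group for another at this position moved the number no further than the scatter. A step of similar modest size, or none beyond the scatter, is therefore expected here as a 1.5-fold higher number from compound 2 to compound 3 (0.18 log units; within the scatter). Compound 3 is estimated to give about 50000 nM in this assay, within a range from 15000 nM to 160000 nM.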

Compound 3, half-maximal inhibitory concentration: > 200000 nM
Compound 3: a limit, no number; the forecaster's own chance of this, stated with the estimate: 15%; at least 4.0-fold (0.60 log units) between middle value and limit.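

For compound 3 the reading in this assay is a limit and not a number: the limit of > 200000 nM in this assay, at which 1 of the 3 values shown sits. The earlier swap between two ring-bearing amine groups stayed within the scatter, but the open-chain (2-(methylamino)ethyl)amino group gives a clear step, with an at least 6.0-fold higher number from compound 2 to compound 3 (0.77 log units; beyond the scatter) and an at least 3.1-fold higher number from compound 1 to compound 3 (0.49 log units; beyond the scatter). This position, ortho to a fluoro group, therefore does not treat all amine groups alike: among the three compounds, the two with a ring give measurable numbers and the one with an open chain does not.

As far as these compounds go, how far compound 3 really lies past its limit remains unknown. From the compounds shown here alone, it also remains open whether any open chain behaves this way, or only this one: a longer chain such as (3-(methylamino)propyl)amino, or the chain with a primary amine, (2-aminoethyl)amino, would test that.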